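Chloro position change from compound 2 to compound 3

The source may report more compounds than this note shows. Statements on the series, on what has been measured and on what is new or still open speak of the compounds shown alone.

Measured compounds:
compound 1 `CC(C)(C)c1ccc(CN2C(=O)S/C(=C\c3ccc(N)cc3)C2=O)cc1`, 66000 nM
compound 2 `Nc1ccc(/C=C2\SC(=O)N(Cc3ccc(Cl)cc3)C2=O)cc1`, 87000 nM

In a functional assay on CCRF-CEM cells (Homo sapiens) for cytotoxicity, read by cell counting, with a stated time of 3 days (on this read-out higher numbers stand for weaker inhibition and lower numbers for stronger inhibition), compound 2 gives 87000 nM. Compound 1 gives 66000 nM in this assay, and the two values lie within the scatter of each other: a 1.3-fold higher number from compound 1 to compound 2 (0.12 log units; within the scatter). Compound 2 therefore stands with compound 1 on the numbers shown, with no order between them beyond the scatter.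

The unmeasured compound 3 `Nc1ccc(/C=C2\SC(=O)N(Cc3cccc(Cl)c3)C2=O)cc1` differs from compound 2 in one place: 3-chlorophenyl in place of 4-chlorophenyl on a saturated chain carbon bound to an amide-type nitrogen in a ring.

Within the data shown here, no measured step bears directly on this change; the only step available, a 1.3-fold higher number from compound 1 to compound 2 (0.12 log units; within the scatter), exchanges one group for another on the same aromatic carbon and stays within the scatter. Among the measured compounds shown here, the move of the chlorine from the 4-chlorophenyl to the 3-chlorophenyl arrangement has no counterpart among the measured compounds, so the expectation for this assay is a step of no particular direction, a 1.1-fold lower number from compound 2 to compound 3 (0.04 log units; within the scatter), not beyond the scatter. Compound 3 is estimated at 80000 nM in this assay, with a range from 35000 nM to 200000 nM.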

Compound 3, half-maximal inhibitory concentration: 18000 nM
For compound 3 the middle estimate is 4.4-fold (0.65 log units) above the measured one; measured number outside the range, below it.
By their numbers in this assay, from the lowest: compound 3; then compounds 1 and 2 (each within the scatter of the next).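

In this assay this position responds to where the chlorine sits on the ring, not only to which group is present: the move gives a 4.8-fold lower number from compound 2 to compound 3 (0.68 log units; beyond the scatter) while the group keeps the same heavy atoms and the same counts. The only earlier step, a 1.3-fold higher number from compound 1 to compound 2 (0.12 log units; within the scatter) for chloro in place of tert-butyl on an aromatic carbon, stayed within the scatter, so until now the series had shown no response to a change on this aryl group. No measurement in hand accounts for the size or direction of the new step.

On these data alone, whether this step belongs to chlorine itself or to the 3-substituted arrangement in general stays open, and a 3-bromophenyl or 3-methoxyphenyl group in place of 3-chlorophenyl, or a 3-tert-butylphenyl group set against compound 1, would separate the two readings. The 2-chlorophenyl group lies outside the compounds shown, so the order across all three chlorine arrangements remains unknown, and a single pair cannot say whether the step would carry over to other changes on the shared core.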